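Swapping the Aryl Group on a Piperazine Sulfonamide

The source may report more compounds than this note shows. Statements on the series, on what has been measured and on what is new or still open speak of the compounds shown alone.

Compound 1 `COC(=O)c1ccc(C2SCC(=O)N2c2ccc(N3CCN(Cc4cccc([N+](=O)[O-])c4)CC3)cn2)c(OC)c1` — > 100000 nM
Compound 2 `COC(=O)c1ccc(C2SCC(=O)N2c2ccc(N3CCN(S(=O)(=O)c4cc(Cl)ccc4Cl)CC3)cn2)c(OC)c1` — 27400 nM

For the measured compounds named here, in a functional assay on NALM-6 cells (Homo sapiens) for antiproliferative activity, read by MTT assay and trypan blue exclusion, with a stated time of 72 h (a lower number here means a stronger inhibitor, a higher number a weaker inhibitor), compound 2 gives 27400 nM, the only actual number among the two results, and a weak one. Compound 1 reaches only the assay limit of > 100000 nM (the limit of > 100000 nM in this assay, at which 1 of the 2 values shown sits). Going by the values given here, the single measured step, an at least 3.6-fold lower number from compound 1 to compound 2 (0.56 log units; beyond the scatter), replaced the whole group on the piperazine nitrogen and at least modestly strengthened the inhibitor, but it tells nothing about exchanging one aryl ring for another on the sulfonyl sulfur. Compound 3 `COC(=O)c1ccc(C2SCC(=O)N2c2ccc(N3CCN(S(=O)(=O)c4c(C)cc(C)cc4C)CC3)cn2)c(OC)c1` differs from compound 2 by 2,4,6-trimethylphenyl in place of 2,5-dichlorophenyl on a sulfonyl sulfur. Among the compounds with values here, no measured step covers this change, so for compound 3 a weak inhibitor close to compound 2 is expected, with a 1.3-fold higher number from compound 2 to compound 3 (0.11 log units; within the scatter) lying inside the usual scatter. The estimate for compound 3 is 35000 nM, ranging from 9000 nM to 130000 nM, with a real chance that only a limit is reported.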

Compound 3, half-maximal inhibitory concentration: > 100000 nM
Compound 3 was reported as a limit (the forecaster's own chance of this, stated with the estimate: 35%); middle value at least 2.8-fold (0.45 log units) from the limit.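

On the sulfonyl sulfur, the choice of aryl ring matters: in this assay, 2,4,6-trimethylphenyl in place of 2,5-dichlorophenyl gives an at least 3.6-fold higher number from compound 2 to compound 3 (0.56 log units; beyond the scatter). The earlier step replaced the whole group on the piperazine nitrogen, whereas here the sulfonyl stays, and compound 3 still gives only a limit rather than a number, so a sulfonyl at this nitrogen does not by itself secure a measurable value. Compound 2 is therefore the only one of the three with a true number, and the rest of the series sits at the ceiling: the limit of > 100000 nM in this assay, at which 2 of the 3 values shown sit.

On these data alone, the step from compound 1 to compound 3 cannot be read, as both results are limits, and the true size of the loss from compound 2 also stays unknown. As far as these compounds go, it remains open whether an unsubstituted phenyl or a 4-methoxyphenyl on the sulfonyl sulfur would give a number.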